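From a hydroxy-methoxy arm to a bromo-fluoro arm

The source may report more compounds than this note shows. Statements on the series, on what has been measured and on what is new or still open speak of the compounds shown alone.

Measured compounds:
compound 1, `O=C(N/N=C/c1ccc([N+](=O)[O-])cc1)c1ccc(-c2nc3ccccc3s2)cc1`: 26400 nM
compound 2, `COc1ccc(/C=N/NC(=O)c2ccc(-c3nc4ccccc4s3)cc2)cc1O`: "not active" (no number reported)

In an assay on isolated protein for inhibition of Maltase-glucoamylase (Homo sapiens), with a stated time of 15 min (on this read-out lower numbers stand for stronger inhibition and higher numbers for weaker inhibition), compound 1 gives 26400 nM, which is weak inhibition. In this assay compound 2 is recorded as "not active" (no number reported), so no number stands for compound 2 and its place cannot be set against compound 1 beyond the statement that no inhibition was seen. Compound 3, `O=C(N/N=C/c1ccc(F)c(Br)c1)c1ccc(-c2nc3ccccc3s2)cc1`, has not been measured. It differs from compound 2 by 3-bromo-4-fluorophenyl in place of 3-hydroxy-4-methoxyphenyl on a carbon with a double bond to nitrogen. Among the compounds with values here, since compound 2 has no number, no step between measured compounds can be drawn for this change, and the only anchor is the weak value of compound 1. The expectation for compound 3 is therefore weak inhibition at best, with a real chance that it is again reported without a number. Compound 3 is expected to give about 40000 nM in this assay, estimated to fall between 10000 nM and 200000 nM.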

Compound 3, half-maximal inhibitory concentration: 28000 nM
Beside the measured number, compound 3's estimate is 1.4-fold (0.15 log units) above it; low and high end bracket the measured number.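

In this assay, putting 3-bromo-4-fluorophenyl in place of 4-nitrophenyl on a carbon with a double bond to nitrogen gives a 1.1-fold higher number from compound 1 to compound 3 (0.03 log units; within the scatter), so the two groups cannot be told apart here. Compound 3 therefore provides a second number for this position, while compound 2, carrying 3-hydroxy-4-methoxyphenyl in the same place, is recorded as "not active", so the step to compound 3 cannot be read as a size. No measured evidence bears on why these results arise. As far as these compounds go, it remains open whether a group such as aminophenyl or carboxyphenyl at this position would give a number clearly different from these two. The compounds shown also cannot separate what the bromine and the fluorine each contribute.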